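This account rests on a few compounds, and the source may have more. Where it says the series, first, only, none or still open, it means among the compounds named here.

Among the compounds with values here, compound 2 `COC(=O)[C@@H]1C2CCC(C[C@H]1c1ccc(F)c(Cl)c1)[S+]2[O-]` is the compound with the higher of the two numbers measured so far in an assay on Caudate-putamen for displacement of a labelled ligand from Transporter (Macaca mulatta); on this read-out higher numbers stand for weaker inhibition and lower numbers for stronger inhibition: compound 2 gives 23 nM, while compound 1 `COC(=O)[C@@H]1C2CCC(C[C@H]1c1ccc(Cl)c(Cl)c1)[S+]2[O-]` gives 7.8 nM. The measured step between them, a 2.9-fold higher number from compound 1 to compound 2 (0.47 log units; beyond the scatter), also consisted of a fluoro in place of a chloro on the ring, so it is the one result that bears on the next change. Compound 3 `COC(=O)[C@@H]1C2CCC(C[C@H]1c1ccc(F)c(F)c1)[S+]2[O-]` differs from compound 2 by fluoro in place of chloro on an aromatic carbon. A modest rise in this assay of similar size is therefore expected, the estimated step being a 2.4-fold higher number from compound 2 to compound 3 (0.38 log units; beyond the scatter). Compound 3 is thus expected at 55 nM, with a range of 25 nM to 130 nM.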

Compound 3, half-maximal inhibitory concentration: 89 nM
Estimate against measurement, compound 3: 1.6-fold (0.21 log units) below; the measured number falls inside the stated range.
By their numbers in this assay, from the lowest: compound 1; then compound 2; then compound 3.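

In this assay, the chloro that stands ortho to a fluoro group and meta to a large group also responds to replacement by fluoro, giving a 3.9-fold higher number from compound 2 to compound 3 (0.59 log units; beyond the scatter). The earlier change, a 2.9-fold higher number from compound 1 to compound 2 (0.47 log units; beyond the scatter), concerned the other chloro on the ring, so the same replacement has now raised the number at both places, and no compound shown goes against this. No available evidence accounts for either rise. From the compounds shown here alone, how a bromo, methyl or methoxy group would read at this position remains open.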